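A few compounds are considered here, and "the series" means these few. Any claim that something is new, unique, unknown or untested is made for them only; others in the source may bear on it.

Measured compounds: compound 2 `c1ccc2c(c1)CN[C@@H](CN(CCCCNCC1CCNCC1)[C@H]1CCCc3cccnc31)C2` gives 36.5 nM in a functional assay on cells for antagonist activity at C-X-C chemokine receptor type 4 (Homo sapiens), read by fluorescence and calcium flux, with stated times of 25 min and 90 s; a lower number here means a stronger inhibitor, a higher number a weaker inhibitor; compound 1 `c1ccc2c(c1)CN[C@@H](CN(CCCCNCC1CCOCC1)[C@H]1CCCc3cccnc31)C2` gives 52.9 nM. Compound 2 holds the lowest of the two numbers, yet the gap to compound 1 is within the scatter.

Compound 3 `O=S1(=O)CCC(CNCCCCN(C[C@H]2Cc3ccccc3CN2)[C@H]2CCCc3cccnc32)CC1` is not yet measured. The change: 1,1-dioxothian-4-yl in place of piperidin-4-yl on a saturated chain carbon bound to an amine nitrogen. Within the data shown here, the one step that bears on it, a 1.4-fold lower number from compound 1 to compound 2 (0.16 log units; within the scatter), exchanged another six-membered saturated ring at the same place and stayed within the scatter. A step of no more than that size is therefore expected here, if anything toward a higher number as in compound 1, which gave 52.9 nM.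

Compound 3 is estimated at 55 nM, range 20 nM to 150 nM, meaning an expected step of a 1.5-fold higher number from compound 2 to compound 3 (0.18 log units; within the scatter).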

Compound 3, half-maximal inhibitory concentration: 17 nM
The estimate for compound 3 lay 3.2-fold (0.51 log units) above the measured number; the measured number lies below the stated range.
By their numbers in this assay, from the lowest: compound 3; then compounds 2 and 1 (each within the scatter of the next).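

In this assay, the ring at this place, on a saturated chain carbon bound to an amine nitrogen, can shift the number beyond the scatter: a 2.1-fold lower number from compound 2 to compound 3 (0.33 log units; beyond the scatter) and a 3.1-fold lower number from compound 1 to compound 3 (0.49 log units; beyond the scatter). The 1,1-dioxothian-4-yl ring has 0 hydrogen-bond donors, so a donor in this ring is not required for the lowest number in the series. No measurement in hand accounts for the step.

Going by these compounds, whether the lower number needs the ring remains open, since an open-chain methylsulfonyl group could do as well or worse. On these data alone, how a ring sulfonamide would compare is also open.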